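The source may hold more compounds than are shown below. What is called first, only, known or untested is meant among the compounds shown, and "the series" means these compounds.

Measured compounds:

Compound 1, `N#Cc1ccc2[nH]c(-c3ccc4[nH]c(-c5cccc6ccccc56)nc4c3)nc2c1`: in a functional assay on RPMI 8402 cells (Homo sapiens) for cytotoxicity (a higher number here means a weaker inhibitor, a lower number a stronger inhibitor), compound 1 gives 650 nM.
Compound 2, `CN1CCN(c2ccc3[nH]c(-c4ccc5[nH]c(-c6ccccc6)nc5c4)nc3c2)CC1`: in this assay compound 2 gives 490 nM.
Compound 3, `Cc1cccc(-c2nc3cc(-c4nc5cc(N6CCN(C)CC6)ccc5[nH]4)ccc3[nH]2)c1`: in this assay compound 3 gives 360 nM.

Among the compounds with values here, compound 3 shows the lowest of the three numbers, but the gaps to compound 2 and to compound 1 both lie within the usual scatter, so no compound can be called stronger than another on these values.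

Compound 4, `CN1CCN(c2ccc3[nH]c(-c4ccc5[nH]c(-c6cccc7ccccc67)nc5c4)nc3c2)CC1`, has not been measured. It differs from compound 3 in one place: naphthalen-1-yl in place of 3-methylphenyl on an aromatic carbon. Within the data shown here, only one measured step touches this part of the molecule, the one from compound 2 to compound 3, where a methyl was added: a 1.4-fold lower number from compound 2 to compound 3 (0.13 log units; within the scatter). Compound 1 carries the same naphthalen-1-yl group as compound 4, with a different group on the other end of the core, and its value sits close to those of compound 2 and compound 3. Nothing here points to a change beyond the scatter. The step from compound 3 to compound 4 is therefore expected to be small, a 1.3-fold higher number from compound 3 to compound 4 (0.10 log units; within the scatter). Compound 4 is estimated at 450 nM, likely between 200 nM and 1000 nM.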

Compound 4, half-maximal inhibitory concentration: 330 nM
For compound 4 the middle estimate is 1.4-fold (0.13 log units) above the measured one; the measured number falls inside the stated range.
By their numbers in this assay, from the lowest: compounds 4, 3, 2 and 1 (each within the scatter of the next).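

In this assay, the position between two ring nitrogen atoms now carries a second ring system: naphthalen-1-yl, with 10 heavy atoms and 2 six-membered aromatic rings, replaces 3-methylphenyl, with 7 heavy atoms and one such ring, and the result is a 1.1-fold lower number from compound 3 to compound 4 (0.04 log units; within the scatter). Set against the unsubstituted phenyl group, the same change gives a 1.5-fold lower number from compound 2 to compound 4 (0.17 log units; within the scatter), so neither comparison separates these aryl groups, and the added ring has no measurable effect on this read-out. With naphthalen-1-yl held constant, a change at the other end of the molecule, 4-methylpiperazin-1-yl in place of cyano, gives a 2.0-fold lower number from compound 1 to compound 4 (0.29 log units; within the scatter), so this pair shows no clear effect of that change either, and no measured evidence is available to explain these small differences.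

On these data alone, every group at the first position is still an all-carbon aromatic ring, so it remains open whether a pyridine ring, a saturated ring such as cyclohexyl, or a group bearing a carboxylic acid would move the number beyond the scatter. At the other end, only nitrile and 4-methylpiperazin-1-yl appear, leaving open what a morpholine ring or a primary amine would do.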